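From Methoxy to Hydroxy at the Limit of the Assay

A few compounds are considered here, and "the series" means these few. Any claim that something is new, unique, unknown or untested is made for them only; others in the source may bear on it.

Three closely related compounds have been tested in an ADME assay on DU-145 cells (Homo sapiens) for cytotoxicity, read by MTT assay, with a stated time of 72 h; a higher number here means a weaker inhibitor, a lower number a stronger inhibitor. Compound 1 `COc1ccc(C2=C(c3cc(OC)c(OC)c(OC)c3)CC(O)C2=O)cc1[N+](=O)[O-]` gives > 100 ug/mL, which is a limit of the assay and not a number. Compound 2 `COc1cc(C2=C(c3cc(C)c(OC)c(C)c3)C(OC(C)=O)CC2=O)cc(OC)c1OC` gives > 100 ug/mL, which is also a limit. Compound 3 `COc1ccc(C2=C(c3cc(OC)c(OC)c(OC)c3)C(=O)CC2O[SiH2]C(C)(C)C)cc1OC` gives > 100 ug/mL, a limit once more. Compound 3 therefore has no number of its own and stands with the other two at the limit of > 100 ug/mL in this assay, at which 3 of the 3 values shown sit.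

Compound 4 `COc1ccc(C2=C(c3cc(OC)c(OC)c(OC)c3)C(=O)CC2O[SiH2]C(C)(C)C)cc1O` differs from compound 3 in one place: hydrogen in place of methyl on an oxygen on an aromatic ring. This puts hydrogen in place of methyl on an oxygen on an aromatic ring, so that 3,4-dimethoxyphenyl becomes 3-hydroxy-4-methoxyphenyl. Among the compounds with values here, no measured pair shows what this change does in this assay, so the size of any step remains open. Since compound 3 starts from the limit of > 100 ug/mL, a measurable result could lie only toward lower numbers, meaning stronger inhibition. A modest gain is expected, although compound 4 may well remain at the limit. The estimated change is an at least 2.5-fold lower number from compound 3 to compound 4 (0.39 log units; beyond the scatter). For compound 4 the expected value is 40 ug/mL, with an estimated range of 3 ug/mL to 130 ug/mL.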

Compound 4, half-maximal inhibitory concentration: 75 ug/mL
Compound 4: the middle estimate sits 1.9-fold (0.27 log units) below what was measured; measured number inside the range.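

In this assay, replacing methoxy with hydroxy, which turns 3,4-dimethoxyphenyl into 3-hydroxy-4-methoxyphenyl, gives an at least 1.3-fold lower number from compound 3 to compound 4 (0.12 log units; that floor lies within the scatter), so this one change is enough to bring a compound of this series to a readable number, although the floor of the step does not clear the scatter. Compound 3 carries only a limit, > 100 ug/mL, and the step therefore has a lower bound and no measured size. Of the four values shown, only that of compound 4 is a number, and the others remain at one shared line: the limit of > 100 ug/mL in this assay, at which 3 of the 4 values shown sit.

The compounds shown leave open whether another group in place of the hydroxy, such as an amine or a carboxylic acid, would carry the number lower still or return it to the limit. They also leave open whether the same exchange of methoxy for hydroxy would bring a readable number in other members of the series, as it is seen here in a single pair only.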